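Aromatic substitution in the vinyl sulfoxide series: compound 4

The source may hold more compounds than are shown below. What is called first, only, known or untested is meant among the compounds shown, and "the series" means these compounds.

Measured in a functional assay on A549 cells (Homo sapiens) for cytotoxicity, with a stated time of 48 h; a lower number here means a stronger inhibitor, a higher number a weaker inhibitor:
compound 1, `Cc1ccc2oc(/C=C/[S+](C)[O-])cc(=O)c2c1`: 1700 nM
compound 2, `C[S+]([O-])/C=C/c1cc(=O)c2ccccc2o1`: 1900 nM
compound 3, `Cc1cccc2c(=O)cc(/C=C/[S+](C)[O-])oc12`: 1700 nM

Compound 2 holds the highest of the three numbers, yet its steps to compound 1 and to compound 3 are both within the scatter, so the three compounds stand level in this assay. The two measured steps are a 1.1-fold higher number from compound 1 to compound 2 (0.05 log units; within the scatter) and a 1.1-fold lower number from compound 2 to compound 3 (0.05 log units; within the scatter); each exchanges hydrogen and methyl on an aromatic carbon of the shared core and neither moves the number beyond the scatter.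

Compound 4 `CCCC(=O)Oc1ccc2oc(/C=C/[S+](C)[O-])cc(=O)c2c1` differs from compound 2 by (propylcarbonyl)oxy in place of hydrogen on an aromatic carbon. The entering group sits on an aromatic carbon of a six-membered aromatic ring of carbon only, part of a fused system of two rings, meta to a fused ring and para to a fused ring. The measured steps bear on it only in that they also vary an aromatic carbon of the same core; none of them places a group of 6 heavy atoms with 2 hydrogen-bond acceptors there. The expectation for compound 4 is therefore a step of no change at the digits printed from compound 2 to compound 4 (within the scatter), with no clear direction and a widened range to cover the larger group. Compound 4 is estimated at 1900 nM, between 800 nM and 4500 nM.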

Compound 4, half-maximal inhibitory concentration: 2200 nM
The estimate for compound 4 lay 1.2-fold (0.06 log units) below the measured number; the measured number falls inside the stated range.
By their numbers in this assay, from the lowest: compounds 1, 3, 2 and 4 (each within the scatter of the next).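

In this assay the aromatic carbon meta to a fused ring and para to a fused ring carries (propylcarbonyl)oxy, a group of 6 heavy atoms with 2 hydrogen-bond acceptors, and the exchange for hydrogen gives a 1.2-fold higher number from compound 2 to compound 4 (0.06 log units; within the scatter) with no separation from the other compounds. The exchange for methyl at the same carbon gives a 1.3-fold higher number from compound 1 to compound 4 (0.11 log units; within the scatter) and so also stays within the scatter, which means that hydrogen, methyl and (propylcarbonyl)oxy stand level at this position, and the earlier finding for a small group now extends to a much larger one in these compounds. No supporting data bear on why the number holds level across this change.

The compounds shown leave open whether this level reading would survive at the same carbon with a basic amine, a carboxylic acid or a longer acyl chain, any of which could yet separate from the values seen so far. They also leave open whether (propylcarbonyl)oxy would read the same on the aromatic carbon that carries the methyl in compound 3, and whether any change to the vinyl sulfoxide side would move the number beyond the scatter.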